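This account rests on a few compounds, and the source may have more. Where it says the series, first, only, none or still open, it means among the compounds named here.

Measured so far in a functional assay (IMR-32 cells, Homo sapiens) for inhibition, read by fluorescence, with stated times of 1 h and 13 h; on this read-out lower numbers stand for stronger inhibition and higher numbers for weaker inhibition:
compound 1 `CCNS(=O)(=O)c1ccc(NC2CCCC2)c(NCc2ccccc2)c1` gives 8.2 nM
compound 2 `CCNS(=O)(=O)c1ccc(NC2CCCC2)c(NCc2ccncc2)c1` gives 36 nM
compound 3 `CNS(=O)(=O)c1ccc(NC2CCCCC2)c(NCc2ccccc2)c1` gives 3.7 nM

Compound 3 has the lowest number of the three; its nearest neighbour is compound 1, and the gap between them lies beyond the scatter, as does the larger gap to compound 2. Compound 1 and compound 3 share the same atoms joined differently, and the difference between the two cores is not broken down here.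

Within the core of compound 1, one change has been measured: pyridin-4-yl in place of phenyl on a saturated chain carbon bound to a nitrogen on an aromatic ring. It gave a 4.4-fold higher number from compound 1 to compound 2 (0.64 log units; beyond the scatter).

Compound 4 `CNS(=O)(=O)c1ccc(NC2CCCCC2)c(NCc2ccncc2)c1` is not yet measured. It differs from compound 3 by pyridin-4-yl in place of phenyl on a saturated chain carbon bound to a nitrogen on an aromatic ring. This is the same change as that from compound 1 to compound 2, made on the core of compound 3 instead; the place of the change is described in the same words in both pairs.

The expectation for compound 4 rests on a single earlier instance of the change, so it is held loosely. The step from compound 3 to compound 4 in this assay is expected to be a 4.3-fold higher number from compound 3 to compound 4 (0.64 log units; beyond the scatter), roughly matching the earlier step because compound 1 to compound 2 gave a 4.4-fold higher number from compound 1 to compound 2 (0.64 log units; beyond the scatter). Compound 4 is therefore estimated at 16 nM in this assay, with a range from 7 nM to 40 nM. Whether the second core carries the change as the first did is exactly what the measurement will show.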

Compound 4, half-maximal inhibitory concentration: 15 nM
Estimate against measurement, compound 4: 1.1-fold (0.03 log units) above, and the stated range covers the measured number.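

In this assay, the second core repeats what the first showed: pyridin-4-yl in place of phenyl on a saturated chain carbon bound to a nitrogen on an aromatic ring gives a 4.1-fold higher number from compound 3 to compound 4 (0.61 log units; beyond the scatter), a step beyond the scatter in the same direction as the earlier one. Set side by side, the two steps do not differ, so in this series the size of the change carried from one core to the other: the same change on two cores in this assay, a 4.4-fold higher number (0.64 log units; beyond the scatter) from compound 1 to compound 2 and a 4.1-fold higher number (0.61 log units; beyond the scatter) from compound 3 to compound 4, 1.1-fold (0.03 log units) apart, within the scatter of two such steps. This shows transfer across two cores in one cellular assay only; it does not show that the step would hold on a further core or on another read-out, and it says nothing about why the pyridine nitrogen costs this much.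

The compounds shown leave open whether the step depends on where the ring nitrogen sits, since pyridin-3-yl and pyridin-2-yl do not appear among them. They also leave open how other groups at the same place would read on these cores, such as 4-fluorophenyl, a carboxylic acid or a longer chain ending in an amine.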